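The source may report more compounds than this note shows. Statements on the series, on what has been measured and on what is new or still open speak of the compounds shown alone.

Measured compounds:
- compound 1 `COc1cc(OC)c(C(=O)/C=C/c2cn(-c3ccccc3)nc2-c2cccnc2)c(OC)c1`: 1300 nM
- compound 2 `COc1ccc(OC)c(C(=O)/C=C/c2cn(-c3ccccc3)nc2-c2cccnc2)c1`: 2700 nM
- compound 3 `COc1cc(OC)c(C(=O)/C=C/c2cn(-c3ccccc3)nc2-c2ccncc2)c(OC)c1`: "not toxic" (no number reported)

In an ADME assay on MRC5 cells (Homo sapiens) for inhibition, read by sulforhodamine B assay, with a stated time of 72 h (on this read-out higher numbers stand for weaker inhibition and lower numbers for stronger inhibition), compound 1 gives 1300 nM, while compound 2 gives 2700 nM. Of the two numbers reported, compound 2 carries the higher one, and its gap to compound 1 lies beyond the usual scatter, so compound 2 is the weaker inhibitor of these two. Compound 3 is reported as "not toxic" (no number reported), without a number.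

Compound 4 `COc1ccc(OC)c(C(=O)/C=C/c2cn(-c3ccccc3)nc2-c2ccncc2)c1` has not been tested in this assay. It differs from compound 2 in one place: pyridin-4-yl in place of pyridin-3-yl on an aromatic carbon. The same exchange separates compound 1 from compound 3, and there a measurable number gave way to a result reported without any number. Going by the values given here, no measured step exists for that pair, so only its two values can speak, but they suggest that the exchange weakens inhibition markedly. The expected step of a 5.6-fold higher number from compound 2 to compound 4 (0.74 log units; beyond the scatter) is therefore toward weaker inhibition, well beyond the scatter, with a real chance that only a limit will be reported. Compound 4 is expected to give about 15000 nM, within a range from 4000 nM to 60000 nM.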

Compound 4, half-maximal inhibitory concentration: 3100 nM
For compound 4 the middle estimate is 4.8-fold (0.68 log units) above the measured one; the whole stated range lies above it.
By their numbers in this assay, from the lowest: compound 1; then compounds 2 and 4 (each within the scatter of the next).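

In this assay the exchange of pyridin-3-yl for pyridin-4-yl gives a 1.1-fold higher number from compound 2 to compound 4 (0.06 log units; within the scatter) and so, in this pair, moving the ring nitrogen of the pyridine leaves no difference that can be told from ordinary repeat variation. The same exchange led from compound 1 to a result without any number, whereas compound 4 keeps a measurable value of 3100 nM and the exchange therefore does not have one outcome across both pairs. Nothing available here explains this difference between the two pairs.

From the compounds shown here alone, compound 3 has no number, so the size of the exchange in that pair remains open. Also open, going by these compounds, is how this position would respond to something other than a pyridine, such as a plain phenyl ring, a morpholine or a carboxylic acid.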